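Moving the chlorine on a benzylamine substituent of the shared core

This account rests on a few compounds, and the source may have more. Where it says the series, first, only, none or still open, it means among the compounds named here.

Of the compounds shown here, three built on the shared core have been measured. Compound 1 `COc1cc(/C=C/c2nc(N3CCN(C)CC3)c3sccc3n2)cc(OC)c1OC` carries a 4-methylpiperazin-1-yl group; in a functional assay on L02 cells (Homo sapiens) for inhibition, read by Griess assay, with stated times of 1 h and 24 h (a lower number here means a stronger inhibitor, a higher number a weaker inhibitor), compound 1 gives > 1000000 nM, which is a limit of the assay and not a number. Compound 2 `COc1ccc(CNc2nc(/C=C/c3cc(OC)c(OC)c(OC)c3)nc3ccsc23)cc1` carries a (4-methoxybenzyl)amino group in its place, and in this assay compound 2 gives > 1000000 nM, again a limit. Compound 3 `COc1cc(/C=C/c2nc(NCc3ccc(Cl)cc3)c3sccc3n2)cc(OC)c1OC` carries a (4-chlorobenzyl)amino group, and in this assay compound 3 gives > 1000000 nM, also a limit. Compound 3 therefore stands where every measured compound stands, at the limit noted as the limit of > 1000000 nM in this assay, at which 3 of the 3 values shown sit. The steps a step that the two limits leave unreadable from compound 1 to compound 2, a step that the two limits leave unreadable from compound 1 to compound 3 and a step that the two limits leave unreadable from compound 2 to compound 3 cannot be sized, because both ends sit at that limit.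

Compound 4 `COc1cc(/C=C/c2nc(NCc3ccccc3Cl)c3sccc3n2)cc(OC)c1OC` differs from compound 3 in one place: 2-chlorophenyl in place of 4-chlorophenyl on a saturated chain carbon bound to a nitrogen on an aromatic ring. Within the data shown here, the only measured step touching the chlorobenzyl group, a step that the two limits leave unreadable from compound 2 to compound 3, is unreadable, so no measured step gives a sized precedent. With every neighbour at the limit, the step of a number no higher from compound 3 to compound 4 (the limit leaves the size open) is expected to show nothing beyond the scatter, and compound 4 is expected to remain at the limit. The estimate for compound 4 is 1000000 nM, within 200000 nM to 5000000 nM.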

Compound 4, half-maximal inhibitory concentration: > 1000000 nM
Compound 4 gave a limit, no number; the forecaster's own chance of this, stated with the estimate: 85%; the middle value sits exactly at the limit.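

In this assay compound 4 gives > 1000000 nM, a limit and not a number. Its steps to compound 1, compound 2 and compound 3 therefore cannot be read, and all four compounds stand together: the limit of > 1000000 nM in this assay, at which 4 of the 4 values shown sit. The compounds shown leave open whether 2-chlorophenyl and 4-chlorophenyl differ at all in this assay, and whether any group on the shared core gives a readable value.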